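Series notes: ethyl in place of chloro on compound 2

This account rests on a few compounds, and the source may have more. Where it says the series, first, only, none or still open, it means among the compounds named here.

The series holds compound 1 `C=C1[C@H](n2ccc(=O)[nH]c2=O)O[C@H](CO)[C@H]1O` and compound 2 `C=C1C(n2cc(Cl)c(N)nc2=O)O[C@H](CO)[C@@H]1O`, both tested in a functional assay on L1210 cells (Mus musculus) for cytotoxicity; on this read-out lower numbers stand for stronger inhibition and higher numbers for weaker inhibition. In this assay compound 1 gives only a limit, > 100 ug/mL. In this assay compound 2 likewise gives only a limit, > 100 ug/mL. Among the measured compounds shown here, compound 2 therefore stands at the limit of > 100 ug/mL in this assay, at which 2 of the 2 values shown sit; no numbered value sits anywhere in the set, so no measured step between compounds is available. Compound 3 `C=C1C(n2cc(CC)c(N)nc2=O)O[C@H](CO)[C@@H]1O` is not yet measured and differs from compound 2 by ethyl in place of chloro on an aromatic carbon, in words: ethyl in place of chloro on an aromatic carbon. With both measured values sitting at the limit, the expected step of a number no higher from compound 2 to compound 3 (the limit leaves the size open) is none beyond the scatter. Compound 3 is expected in this assay to give about 100 ug/mL, within a range of 30 ug/mL to 300 ug/mL, and most probably again only as a limit.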

Compound 3, half-maximal inhibitory concentration: > 100 ug/mL
Compound 3: no number, only a limit; the forecaster's own chance of this, stated with the estimate: 80%; the middle value lies on the limit itself.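

In this assay compound 2 and compound 3 both stand only as limits, so no step between them can be read: the limit of > 100 ug/mL in this assay, at which 3 of the 3 values shown sit.

The compounds shown leave open whether any member of this series gives a numbered value in this assay and how ethyl and chloro compare.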